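Ester Swap Under Mouse Liver Microsomes

A few compounds are considered here, and "the series" means these few. Any claim that something is new, unique, unknown or untested is made for them only; others in the source may bear on it.

Measured compounds:
compound 1, `CCCCc1nc(C)c(CC(=O)OCC)c(=O)n1Cc1ccc(-c2ccccc2-c2noc(=O)[nH]2)cc1`: 12.9%; 78.4% (2 entries)
compound 2, `CCCCOC(=O)Cc1c(C)nc(CCCC)n(Cc2ccc(-c3ccccc3-c3noc(=O)[nH]3)cc2)c1=O`: 10.2%

Among the measured compounds shown here, in an ADME assay on microsomes from liver (Mus musculus) for metabolic stability, with a stated time of 30 min (on this read-out higher numbers stand for a more stable compound and lower numbers for a less stable compound), compound 2 gives 10.2%, the only single number it has; one further entry for it carries no number. Compound 1 is known from the several entries of compound 1 in this assay, 12.9%; 78.4% (2 entries), two entries lying far apart, which shows how widely repeated measurements of this kind can spread for one compound. Compound 3, `CCCCc1nc(C)c(CC(=O)OC2CC2)c(=O)n1Cc1ccc(-c2ccccc2-c2noc(=O)[nH]2)cc1`, has not yet been measured. It differs from compound 2 by cyclopropyl in place of butyl on an oxygen next to a carbonyl group. For the measured compounds named here, no pair of measured compounds here differs in a single place, so there is no measured step to guide this change. The expected step of a number 7.8 percentage points higher from compound 2 to compound 3 (within the scatter) is small, at most a modest rise, and likely not beyond the usual scatter. Compound 3 is therefore expected to give about 18%, with a range from 5% to 55%.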

Compound 3, percent of the compound remaining: 12.8%
For compound 3 the middle estimate is 5.2 percentage points above the measured one; low and high end bracket the measured number.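

Putting cyclopropyl in place of butyl on an oxygen next to a carbonyl group gives a number 2.6 percentage points higher from compound 2 to compound 3 (within the scatter), so this assay does not tell these two compounds apart. Among the compounds shown here, this is the first measured step at this position, and it shows that replacing an open chain with a three-membered ring leaves the read-out within the scatter. Both compounds also sit low on the scale, although a single low reading deserves caution, as repeated entries for one compound can differ widely: the several entries of compound 1 in this assay, 12.9%; 78.4% (2 entries)

The compounds shown leave open whether a tert-butyl group on this oxygen, or an amine in its place, would move the read-out beyond the scatter. They also leave open where compound 1 truly stands, with 12.9%; 78.4% (2 entries), so ethyl cannot yet be placed against butyl or cyclopropyl on this oxygen.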